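The source may report more compounds than this note shows. Statements on the series, on what has been measured and on what is new or still open speak of the compounds shown alone.

Compound 1 `Oc1ccccc1-c1cc(-c2cccc(F)c2)cc(-c2ccccc2O)n1` opens the set. In a functional assay on HeLa cells (Homo sapiens) for inhibition (a lower number here means a stronger inhibitor, a higher number a weaker inhibitor), compound 1 gives only a limit, > 50000 nM. Compound 2 `Oc1cccc(-c2cc(-c3cccc(F)c3)cc(-c3ccccc3O)n2)c1` differs from it by 3-hydroxyphenyl in place of 2-hydroxyphenyl on an aromatic carbon. In this assay compound 2 again gives only a limit, > 50000 nM. The step that the two limits leave unreadable from compound 1 to compound 2 cannot be sized because both values sit at the limit of > 50000 nM in this assay, at which 2 of the 3 values shown sit. Compound 3 `Oc1cccc(-c2cc(-c3ccc(OC(F)(F)F)cc3)cc(-c3ccccc3O)n2)c1` has another core; the difference between its core and that of compound 1 is not broken down here. In this assay, among the measured compounds shown here, compound 3 gives 20600 nM, the only number so far. Compound 4 `Oc1cccc(-c2cc(-c3ccc(OC(F)(F)F)cc3)cc(-c3cccc(O)c3)n2)c1` is still to be measured and differs from compound 3 by 3-hydroxyphenyl in place of 2-hydroxyphenyl on an aromatic carbon. This is the same kind of change as from compound 1 to compound 2, though the place differs: there it was meta to a 2-hydroxyphenyl group and meta to a 3-fluorophenyl group, here it is meta to a 3-hydroxyphenyl group and meta to a large group. The earlier step gives no readable size, so a step of a 1.2-fold higher number from compound 3 to compound 4 (0.08 log units; within the scatter) is expected, little beyond the scatter. Compound 4 is therefore estimated at 25000 nM, between 8000 nM and 80000 nM.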

Compound 4, half-maximal inhibitory concentration: 18700 nM
Compound 4: middle estimate off by 1.3-fold (0.13 log units), on the high side; the measured number falls inside the stated range.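

In this assay, 3-hydroxyphenyl in place of 2-hydroxyphenyl gives a 1.1-fold lower number from compound 3 to compound 4 (0.04 log units; within the scatter), so on this core the change has no effect that can be told from the scatter. Among the compounds shown here, the same change from compound 1 to compound 2 cannot be sized, as both values are limits of the assay: the limit of > 50000 nM in this assay, at which 2 of the 4 values shown sit. The one readable step therefore describes a single core, and it does not show that the change behaves alike on the core of compound 1.

The compounds shown leave open whether an amine or a carboxylic acid in place of the hydroxyl on these rings would shift the number in this assay. They also leave open what a longer chain on the hydroxyl oxygen, such as an ethoxy group, would do.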